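This account rests on a few compounds, and the source may have more. Where it says the series, first, only, none or still open, it means among the compounds named here.

The measured compounds:
Compound 1, `Nc1nc(N)nc(-c2cccc(F)c2)n1`, gives 1.73 in a physicochemical assay for lipophilicity; on this read-out higher numbers stand for higher lipophilicity and lower numbers for lower lipophilicity.
Compound 2, `Nc1nc(N)nc(-c2ccc(F)cc2)n1`, gives 1.61 in this assay.
Compound 3, `Nc1nc(N)nc(-c2cccc([N+](=O)[O-])c2)n1`, gives 1.57 in this assay.

Compound 1 and compound 2 are built from the same atoms joined differently; the difference between the two cores is not broken down here. Their two values lie within the scatter of each other, as do the values of compound 2 and compound 3. Compound 3 arises from compound 1 by one change, (nitro in place of fluoro on an aromatic carbon), and this change gave a number 0.16 log units lower from compound 1 to compound 3 (within the scatter). Compound 4, `Nc1nc(N)nc(-c2ccc([N+](=O)[O-])cc2)n1`, is not yet measured; it arises from compound 2 by nitro in place of fluoro on an aromatic carbon. This is the same kind of change as the earlier one, but the place differs: from compound 1 to compound 3 the group sits meta to a group of 8 heavy atoms, and from compound 2 to compound 4 it sits para to a group of 8 heavy atoms. The step expected in this assay is a number 0.16 log units lower from compound 2 to compound 4 (within the scatter), resting on the earlier step of a number 0.16 log units lower from compound 1 to compound 3 (within the scatter), whose size is carried over. For compound 4 the expected value is 1.45, with an expected range from 1.15 to 1.75.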

Compound 4, partition coefficient: 1.6
Compound 4: middle estimate off by 0.15 log units, on the low side; low and high end bracket the measured number.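

In this assay the swap of nitro in place of fluoro gave a number 0.01 log units lower from compound 2 to compound 4 (within the scatter) and also gave a number 0.16 log units lower from compound 1 to compound 3 (within the scatter) so in both pairs shown, the step cannot be told apart from the scatter of repeated measurements. This does not show that the swap has no effect on lipophilicity, nor that the two steps truly match or differ, since two pairs whose steps both lie within the scatter cannot separate a small real step from noise. Nothing available here explains these values.

The compounds shown leave open what happens when an amine, a carboxylic acid or a longer chain stands on the same aromatic carbon, and whether any of these would give a step beyond the scatter. They also leave open whether the swap of nitro in place of fluoro would behave the same way on cores other than these two.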